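The source may hold more compounds than are shown below. What is called first, only, known or untested is meant among the compounds shown, and "the series" means these compounds.

Measured in a physicochemical assay for solubility, read by HPLC, with a stated time of 24 h; a lower number here means a less soluble compound, a higher number a more soluble compound:
Compound 1 `CC(C)(C)c1[nH]cnc1/C=c1\[nH]c(=O)/c(=C/c2cccc(C(=O)c3cccnc3)c2)[nH]c1=O`: < 0.1 ug/mL (a limit)
Compound 2 `CC(C)(C)c1[nH]cnc1/C=c1\[nH]c(=O)/c(=C/c2cccc(C(=O)c3cccs3)c2)[nH]c1=O`: < 0.1 ug/mL (a limit)

Compound 2 has no number, only the limit < 0.1 ug/mL. It shares its standing with compound 1, as the record shows: the limit of < 0.1 ug/mL in this assay, at which 2 of the 2 values shown sit. Compound 3 `CC(C)(C)c1[nH]cnc1/C=c1\[nH]c(=O)/c(=C/c2cccc(C(=O)c3ccco3)c2)[nH]c1=O` carries furan-2-yl in place of thiophen-2-yl on a carbonyl carbon. Among the compounds with values here, the one measured step that bears on this change is a step that the two limits leave unreadable from compound 1 to compound 2, and it offers no size to carry over. Compound 2 reads < 0.1 ug/mL, a limit, so compound 3 is expected to report the same limit or a value close to it. The expected step is a number no lower from compound 2 to compound 3 (the limit leaves the size open), with no direction beyond the scatter foreseen in this assay. For compound 3 the estimated value is 0.1 ug/mL, with an expected range from 0.05 ug/mL to 0.3 ug/mL.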

Compound 3, solubility: < 0.1 ug/mL
Compound 3: no number, only a limit; the forecaster's own chance of this, stated with the estimate: 70%; the middle value sits exactly at the limit.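

In this assay compound 3 gives < 0.1 ug/mL, which is a limit, so no step among compound 1, compound 2 and compound 3 can be read: the limit of < 0.1 ug/mL in this assay, at which 3 of the 3 values shown sit.

The compounds shown leave open whether pyridin-3-yl, thiophen-2-yl and furan-2-yl on the carbonyl carbon differ at all in this assay.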